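The source may report more compounds than this note shows. Statements on the series, on what has been measured and on what is new or still open speak of the compounds shown alone.

Within the data shown here, compound 1 `CCCN(CCC)c1cc(C(F)(F)F)ccc1CNC(=O)C(C)c1ccc(NS(C)(=O)=O)c(F)c1` gives 0.3 nM in an assay on CHO cells for antagonist activity at transient receptor potential cation channel subfamily V member 1 (Homo sapiens), read by FLIPR (a lower number here means a stronger inhibitor, a higher number a weaker inhibitor), the lowest of the three numbers measured so far. Compound 2 `CCCOc1cc(C(F)(F)F)ccc1CNC(=O)C(C)c1ccc(NS(C)(=O)=O)c(F)c1` gives 2 nM, and compound 3 `CC(C(=O)NCc1ccc(C(F)(F)F)cc1OC1CCCCC1)c1ccc(NS(C)(=O)=O)c(F)c1` gives 0.7 nM. Compound 4 `CC(C(=O)NCc1ccc(C(F)(F)F)cc1OCc1ccccc1)c1ccc(NS(C)(=O)=O)c(F)c1` differs from compound 1 by benzyloxy in place of dipropylamino on an aromatic carbon. Among the measured compounds shown here, two measured steps bear on this change, both replacing the dipropylamino with a group joined through oxygen: a 6.7-fold higher number from compound 1 to compound 2 (0.82 log units; beyond the scatter) and a 2.3-fold higher number from compound 1 to compound 3 (0.37 log units; beyond the scatter). Between those two oxygen-linked compounds, a 2.9-fold lower number from compound 2 to compound 3 (0.46 log units; beyond the scatter). Since compound 4 also carries a group joined through oxygen, with a ring in it like compound 3, a modestly higher number than that of compound 1 is expected, a 3.3-fold higher number from compound 1 to compound 4 (0.52 log units; beyond the scatter). Compound 4 is therefore estimated at 1 nM, with a range from 0.4 nM to 3 nM.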

Compound 4, inhibition constant: 0.9 nM
Beside the measured number, compound 4's estimate is 1.1-fold (0.05 log units) above it; low and high end bracket the measured number.
By their numbers in this assay, from the lowest: compound 1; then compounds 3 and 4 (each within the scatter of the next); then compound 2.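

Benzyloxy on this aromatic carbon also gives a higher number than the dipropylamino group of compound 1 (a 3.0-fold higher number from compound 1 to compound 4 (0.48 log units; beyond the scatter)), so all three oxygen-linked groups shown sit above it. An aromatic ring in the benzyl group and the saturated cyclohexyl ring cannot be separated (a 1.3-fold higher number from compound 3 to compound 4 (0.11 log units; within the scatter)), while the phenyl on the chain gives a lower number than the propoxy of compound 2 (a 2.2-fold lower number from compound 2 to compound 4 (0.35 log units; beyond the scatter)). Nothing measured here explains these differences.

Going by these compounds, whether another amine, such as dimethylamino, would match dipropylamino remains open. So does the effect of a fluorine or a methoxy group on the benzyl ring.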